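The source may report more compounds than this note shows. Statements on the series, on what has been measured and on what is new or still open speak of the compounds shown alone.

In a functional assay for inhibition, with Homo sapiens as the target (on this read-out lower numbers stand for stronger inhibition and higher numbers for weaker inhibition), compound 1 (`COC(=O)c1cc(-c2ccccc2)c2ccc(OCc3cccc(C4(O)CCOCC4)c3)cc2c1`) gives 3 nM and stands level with compound 2 (`N#Cc1cc(-c2ccccc2)c2ccc(OCc3cccc(C4(O)CCOCC4)c3)cc2c1`), which gives 3 nM in the same read-out. Compound 3 (`COC(=O)c1cc(Cc2ccccc2)c2ccc(OCc3cccc(C4(O)CCOCC4)c3)cc2c1`) keeps the core of compound 1 and its methoxycarbonyl group, but has benzyl in place of phenyl on an aromatic carbon, meta to a methoxycarbonyl group. Going by the values given here, the one measured step, no change at the digits printed from compound 1 to compound 2 (within the scatter) for cyano in place of methoxycarbonyl, stays within the scatter. It touches the methoxycarbonyl group and not the phenyl, so it bears on the new change only indirectly. Among the compounds with values here, no measured compound varies the phenyl, and the data give neither the size nor the direction of this step directly. With nothing measured at this place, a modest loss in this assay is the cautious expectation, since compound 1 already starts from 3 nM on this scale. The expected step is a 2.7-fold higher number from compound 1 to compound 3 (0.43 log units; beyond the scatter) toward weaker inhibition, although no change beyond the scatter also remains possible. Compound 3 is estimated at 8 nM with an expected range from 2 nM to 30 nM in this read-out.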

Compound 3, half-maximal inhibitory concentration: > 70 nM
Compound 3 ended at the assay's limit; the forecaster's own chance of this, stated with the estimate: 3%; middle value at least 8.7-fold (0.94 log units) away from the limit.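

In this assay compound 3 gives > 70 nM, and this value is a limit of the assay, not a number. Benzyl in place of phenyl on this aromatic carbon, ortho to a fused ring and meta to a methoxycarbonyl group, produces an at least 23-fold higher number from compound 1 to compound 3 (1.36 log units; beyond the scatter), so the first measured variation at this place already moves the read-out well beyond the scatter toward weaker inhibition, even though both groups carry one six-membered aromatic ring of carbon only and neither has hydrogen-bond donors or acceptors. The earlier step, no change at the digits printed from compound 1 to compound 2 (within the scatter), showed only that cyano can replace methoxycarbonyl within the scatter, whereas the phenyl position now emerges as the one of these two places where a change has a large effect in this series.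

How far compound 3 lies past its limit stays open, so the full size of the step cannot be given: the limit of > 70 nM in this assay, at which 1 of the 3 values shown sits. The compounds shown also leave open whether a smaller group such as methyl, a longer chain such as 2-phenylethyl, or an amine at this place would hold the inhibition of compound 1, and whether benzyl has the same effect alongside the cyano group of compound 2.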